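A solubility step from chlorophenyl to dimethylphenyl

A few compounds are considered here, and "the series" means these few. Any claim that something is new, unique, unknown or untested is made for them only; others in the source may bear on it.

Compound 1 `Cc1oc(-c2ccccc2Cl)nc1CN1CCC(C(=O)NCCCN2C[C@H](C)C[C@H](C)C2)CC1` gives > 72 ug/mL in a physicochemical assay for solubility, in phosphate buffer, measured as kinetic solubility, at pH 7.4 (a lower number here means a less soluble compound, a higher number a more soluble compound), which is a limit of the assay and not a number.
Compound 2 `Cc1cccc(Cl)c1-c1nc(CN2CCC(C(=O)NCCCN3CCC(C(C)C)CC3)CC2)c(C)o1` gives > 76 ug/mL in this assay, again a limit and not a number.

Compound 1 therefore stands only at a limit in this assay, namely (the limit of > 72 ug/mL in this assay, at which 1 of the 2 values shown sits). Among the measured compounds shown here, the one further value known is likewise a limit, (the limit of > 76 ug/mL in this assay, at which 1 of the 2 values shown sits). For the measured compounds named here, neither reading is a number, so no step between measured compounds can be drawn from them.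

Compound 3 `Cc1cccc(C)c1-c1nc(CN2CCC(C(=O)NCCCN3C[C@H](C)C[C@H](C)C3)CC2)c(C)o1` differs from compound 1 by 2,6-dimethylphenyl in place of 2-chlorophenyl on an aromatic carbon. Going by the values given here, with no measured step to lean on, the step of an at least 1.0-fold lower number from compound 1 to compound 3 (0.01 log units; that floor lies within the scatter) is expected to be none beyond the scatter, since compound 1 already sits at the limit of > 72 ug/mL in this assay, at which 1 of the 2 values shown sits. Compound 3 is thus expected to give about 70 ug/mL, within 30 ug/mL to 130 ug/mL, and most likely to be reported again only as a limit.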

Compound 3, solubility: 55.9 ug/mL
Compound 3: middle estimate off by 1.3-fold (0.10 log units), on the high side, within the range that was stated.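

In this assay compound 3 gives 55.9 ug/mL, the only reading shown so far that is a number and not a limit. Compound 1 stays a limit of the assay and not a number: the limit of > 72 ug/mL in this assay, at which 1 of the 3 values shown sits. The change from 2-chlorophenyl to 2,6-dimethylphenyl gives an at least 1.2-fold lower number from compound 1 to compound 3 (0.10 log units; that floor lies within the scatter), and that step is only a floor, so the compounds cannot show whether the true step goes beyond the scatter.

Compound 2 differs from both of the others in more than one place, so no further step can be read from it. Open too, on these data alone, is how the reading would move with an amine or a carboxylic acid on the phenyl ring at this same position, in place of the chlorine or the methyl groups.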